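The compounds below may be only part of what the source reports. "The series", "measured", "known", "first", "only" and "open" are said of these compounds alone.

Series values in a functional assay on U-87MG ATCC cells (Homo sapiens) for cytotoxicity, read by MTT assay, with a stated time of 48 h; a higher number here means a weaker inhibitor, a lower number a stronger inhibitor:
- compound 1 `C/C(=N\NC(=S)Nc1ccccc1I)c1ccccn1`: 6.1 nM
- compound 2 `CC(=NNC(=S)Nc1cccc([N+](=O)[O-])c1)c1ccccn1`: 69 nM
- compound 3 `C/C(=N\NC(=S)Nc1cccc(F)c1)c1ccccn1`: 18 nM

Compound 1 has the lowest number of the three, and its gaps to compound 3 and compound 2 both lie beyond the scatter. The next analogue, compound 4 `C/C(=N\NC(=S)Nc1ccccc1F)c1ccccn1`, is still unmeasured. It differs from compound 1 as follows: fluoro in place of iodo on an aromatic carbon. In short, compound 4 swaps the iodo of compound 1 for fluoro. Among the compounds with values here, no measured pair isolates this change, so the evidence is indirect. Compound 3 also carries fluoro and gives 18 nM. A modest rise to a higher number, slightly beyond the scatter, is expected in this assay. The expected step is a 2.5-fold higher number from compound 1 to compound 4 (0.39 log units; beyond the scatter). Compound 4 is estimated at 15 nM, with an expected range of 5 nM to 50 nM.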

Compound 4, half-maximal inhibitory concentration: 5 nM
Estimate against measurement, compound 4: 3.0-fold (0.48 log units) above, and the stated range covers the measured number.
By their numbers in this assay, from the lowest: compounds 4 and 1 (each within the scatter of the next); then compound 3; then compound 2.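

In this assay the swap of iodo for fluoro on the aromatic carbon ortho to a large group is a step within the scatter (a 1.2-fold lower number from compound 1 to compound 4 (0.09 log units; within the scatter)). Within the data shown here, this is the first direct pair at this position, and it shows that the read-out does not separate iodo from fluoro here, so the size of the atom leaving does not register in this pair. No measured property bears on this result.

From the compounds shown here alone, whether this position also accepts an amine, a methoxy group or a carboxylic acid stays open, as does the effect of plain hydrogen there.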